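A few compounds are considered here, and "the series" means these few. Any claim that something is new, unique, unknown or untested is made for them only; others in the source may bear on it.

Of the compounds shown here, three sharing one core have been measured so far. Compound 1 `C=CC(=O)N1C(=O)CC(c2ccc(C(=O)OC)cc2)Sc2ccccc21` carries a methoxycarbonyl group on its pendant aromatic ring, compound 2 `C=CC(=O)N1C(=O)CC(C)Sc2ccccc21` has only a methyl group on the saturated ring carbon, and compound 3 `C=CC(=O)N1C(=O)CC(c2ccc(Cl)cc2)Sc2ccccc21` carries a chloro group on the pendant aromatic ring. In a functional assay on HL-60 cells (Homo sapiens) for cytotoxicity, read by CCK-8 assay, with a stated time of 24 h (on this read-out lower numbers stand for stronger inhibition and higher numbers for weaker inhibition), compound 1 gives 102000 nM, compound 2 gives 199000 nM, and compound 3 gives 95700 nM. Compound 3 thus holds the lowest number of the three, but its step from compound 1 is a 1.1-fold lower number from compound 1 to compound 3 (0.03 log units; within the scatter), so these two cannot be told apart, while the step of a 2.1-fold lower number from compound 2 to compound 3 (0.32 log units; beyond the scatter) is modest but beyond the scatter.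

Compound 4 `C=CC(=O)N1C(=O)CC(c2ccccc2)Sc2ccccc21` is the next compound, differing from compound 3 by hydrogen in place of chloro on an aromatic carbon. The step that bears most directly on this change is a 1.1-fold lower number from compound 1 to compound 3 (0.03 log units; within the scatter), which shows that swapping one group for another on the pendant aromatic ring left the number essentially unchanged. The step of a 2.1-fold lower number from compound 2 to compound 3 (0.32 log units; beyond the scatter) shows that the aromatic ring itself matters somewhat, and compound 4 keeps that ring. A step of a 1.1-fold higher number from compound 3 to compound 4 (0.06 log units; within the scatter) in this assay is therefore expected, with no change beyond the scatter. Compound 4 is estimated at 110000 nM, within a range of 60000 nM to 210000 nM.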

Compound 4, half-maximal inhibitory concentration: 97400 nM
Compound 4: middle estimate off by 1.1-fold (0.05 log units), on the high side; the range from low to high includes it.
By their numbers in this assay, from the lowest: compounds 3, 4, 1 and 2 (each within the scatter of the next, the first and the last beyond it).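

With the unsubstituted phenyl ring now measured, the two substituted compounds can be read against a plain reference, which the earlier comparison of chloro with methoxycarbonyl could not provide. Hydrogen in place of chloro (a 1.0-fold higher number from compound 3 to compound 4 (0.01 log units; within the scatter)) and hydrogen in place of methoxycarbonyl (a 1.0-fold lower number from compound 1 to compound 4 (0.02 log units; within the scatter)) both leave the number within the scatter, so neither group, at this place on the aromatic ring, has a detectable effect on the reading compared with no group at all. The modest difference from the methyl compound also survives with nothing on the ring (a 2.0-fold lower number from compound 2 to compound 4 (0.31 log units; beyond the scatter)), which shows that the phenyl ring alone is enough for it, while no measurement is available that could explain these numbers.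

Chloro and methoxycarbonyl are only two groups, so it remains open whether an amine, a hydroxyl group or a carboxylic acid at this place on the ring would shift the number beyond the scatter. On the saturated ring carbon, the compounds shown also leave open how a longer chain, such as propyl, or a benzyl group would compare with the methyl and phenyl groups.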